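A few compounds are considered here, and "the series" means these few. Any claim that something is new, unique, unknown or untested is made for them only; others in the source may bear on it.

Of the compounds shown here, three have been tested in an assay on cells for agonist activity at probable G-protein coupled receptor 34 (Mus musculus), with a stated time of 1 h; a higher number here means a larger maximal response, a lower number a smaller maximal response. Compound 1 `CCCCCCCCCCCOc1ccccc1CCC(=O)OCCCOP(=O)(O)OC[C@H](N)C(=O)O` gives 14.6% in this assay. Going by the values given here, compound 2 `N[C@@H](COP(=O)(O)OCCCOC(=O)CCc1ccccc1OCCCCOc1ccccc1)C(=O)O` gives 6.1% in this assay, and the only single-place step measured so far is a number 8.5 percentage points lower from compound 1 to compound 2 (within the scatter). Compound 3 `N[C@@H](COP(=O)(O)OCCCOC(=O)CCc1ccccc1OCc1cccc(Oc2ccccc2Cl)c1)C(=O)O` gives 19.8% in this assay, the highest of the three numbers; compound 1 sits close to it, within the scatter, while compound 2 lies further off, beyond the scatter.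

The next compound, compound 4 `CCc1ccc(Oc2cccc(COc3ccccc3CCC(=O)OCCCOP(=O)(O)OC[C@H](N)C(=O)O)c2)cc1`, has not yet been measured. It differs from compound 3 in one place: 4-ethylphenyl in place of 2-chlorophenyl on an oxygen on an aromatic ring. The change sits at the far end of the molecule, on an oxygen on an aromatic ring whose other neighbour is an aromatic carbon, and the shared core is untouched.

Among the compounds with values here, no measured step tests this kind of exchange. Within the data shown here, the one step in hand, a number 8.5 percentage points lower from compound 1 to compound 2 (within the scatter), concerns a different position and was itself within the scatter, so it offers no direct guidance. With nothing pointing either way, a step of no more than the scatter is expected, a number 0.2 percentage points higher from compound 3 to compound 4 (within the scatter). Compound 4 is therefore estimated to give about 20% in this assay, plausibly between 8% and 32%.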

Compound 4, largest response reached (Emax), in percent of the reference or control that the assay uses: 19.3%
Estimate against measurement, compound 4: 0.7 percentage points above, within the range that was stated.
By their numbers in this assay, from the lowest: compounds 2, 1, 4 and 3 (each within the scatter of the next, the first and the last beyond it).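

Going by these compounds alone, this is the first measured exchange at this place: on an oxygen on an aromatic ring, 4-ethylphenyl in place of 2-chlorophenyl gives a number 0.5 percentage points lower from compound 3 to compound 4 (within the scatter) in this assay. A chlorine leaves, an ethyl group enters and the substituent's printed ring number changes, yet the maximal response cannot be told apart from that of the parent compound, so this one pair shows that these two carbon-ring groups are interchangeable in this read-out. Nothing measured on these compounds accounts for that outcome.

Because both the identity of the substituent and its printed ring number differ within this single step, the two changes cannot be separated, and a 4-chlorophenyl group would be needed to pull them apart. As far as these compounds go, whether any group at this place can move the response beyond the scatter also stays open, since only these two have been compared here, and an unsubstituted phenyl ring or a ring carrying a nitrile or an amine would test that more widely.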